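This account rests on a few compounds, and the source may have more. Where it says the series, first, only, none or still open, it means among the compounds named here.

Compound 1 `O=C(NO)c1cccc(/C=C/c2ccnc(-c3ccccc3O)c2)c1`: 2810 nM
Compound 2 `COc1ccccc1-c1cc(/C=C/c2ccc(C(=O)NO)cc2)ccn1`: 6350 nM

Both values come from a functional assay on MGC-803 cells (Homo sapiens) for antiproliferative activity, read by CellTiter-Glo, with a stated time of 72 h; a lower number here means a stronger inhibitor, a higher number a weaker inhibitor. Compound 2 has the higher of the two numbers, which makes it the weaker inhibitor of the pair, and the gap to compound 1 lies beyond the usual scatter. Among the measured compounds shown here, these two compounds do not differ in just one place, so no measured step is available to guide a prediction.

Compound 3 `COc1ccc(-c2cc(/C=C/c3ccc(C(=O)NO)cc3)ccn2)cc1` is related to compound 2 by 4-methoxyphenyl in place of 2-methoxyphenyl on an aromatic carbon. The group sits next to the ring nitrogen, meta to a large group. For the measured compounds named here, with no measured precedent for this change, only a modest shift is expected in this assay, with no step beyond the scatter in either direction. The expected step is a 1.3-fold lower number from compound 2 to compound 3 (0.10 log units; within the scatter). For compound 3 the estimated value is 5000 nM, with an expected range from 1700 nM to 14000 nM.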

Compound 3, half-maximal inhibitory concentration: 3510 nM
Beside the measured number, compound 3's estimate is 1.4-fold (0.15 log units) above it; low and high end bracket the measured number.
By their numbers in this assay, from the lowest: compounds 1, 3 and 2 (each within the scatter of the next, the first and the last beyond it).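

Among the compounds shown here, this is the first one-place comparison: in this assay, 4-methoxyphenyl in place of 2-methoxyphenyl, on the aromatic carbon next to the ring nitrogen, gives a 1.8-fold lower number from compound 2 to compound 3 (0.26 log units; within the scatter). Moving the methoxy group around this aryl substituent therefore does not separate the two compounds in this assay, and the step gives no sign that either placement is preferred. No measured evidence bears on this result, so nothing can be said about its cause.

The compounds shown leave open whether 3-methoxyphenyl would behave in the same way, and whether an amine or a carboxylic acid in place of the methoxy group would produce a step beyond the scatter. They also cannot separate the contributions of the two places in which compound 1 and compound 2 differ.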